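A Smaller Group on the Nitro Compound

The compounds below may be only part of what the source reports. "The series", "measured", "known", "first", "only" and "open" are said of these compounds alone.

Measured so far in a functional assay on the whole organism for inhibition, with Cavia porcellus as the target; on this read-out lower numbers stand for an effect already at smaller amounts and higher numbers for an effect only at larger amounts of compound:
- Compound 1 (`CN(C)/C(=N\C#N)C1=CC(C)(C)Oc2ccc([N+](=O)[O-])cc21`) gives 51.3 nM
- Compound 2 (`CN(C)/C(=N\C#N)C1=CC(C)(C)Oc2ccc(C(F)(F)F)cc21`) gives 178 nM

Compound 1 holds the lower of the two numbers. Among the compounds with values here, the one measured step in this small set is a 3.5-fold higher number from compound 1 to compound 2 (0.54 log units; beyond the scatter) and comes from trifluoromethyl in place of nitro on an aromatic carbon.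

Compound 3 (`CN(C)C(=S)C1=CC(C)(C)Oc2ccc([N+](=O)[O-])cc21`) keeps the nitro group of compound 1 and differs on a double-bonded ring carbon (a group of 5 heavy atoms (3 carbon, 1 nitrogen, 1 sulfur; no ring) in place of a group of 7 heavy atoms (4 carbon, 3 nitrogen; no ring), on a double-bonded ring carbon). Within the data shown here, no measured step touches that place. The step to compound 2 therefore bears on the question only indirectly, as a rough guide to how large a single change can be among these compounds. With so little to go on, a modest move towards a higher number in this assay is expected, with wide uncertainty in either direction. The expected step is a 2.9-fold higher number from compound 1 to compound 3 (0.47 log units; beyond the scatter) in this estimate. For compound 3 the estimated value is 150 nM in this assay, with an expected range from 30 nM to 800 nM for the measurement.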

Compound 3, half-maximal effective concentration: 490 nM
Beside the measured number, compound 3's estimate is 3.3-fold (0.51 log units) below it, and the stated range covers the measured number.
By their numbers in this assay, from the lowest: compound 1; then compound 2; then compound 3.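

In this assay, within the data shown here, the double-bonded ring carbon of the shared core, which no earlier step had touched, proves sensitive to change: a group of 5 heavy atoms (3 carbon, 1 nitrogen, 1 sulfur; no ring) in place of a group of 7 heavy atoms (4 carbon, 3 nitrogen; no ring) gives a 9.6-fold higher number from compound 1 to compound 3 (0.98 log units; beyond the scatter). The nitro group stays in place across this pair, so the step belongs to this position alone, whereas the earlier step concerned an aromatic carbon. Nothing at hand explains the size of this step or ties it to any one difference between the two groups, such as the sulfur that enters or the triple bond that leaves.

The compounds shown leave open whether a carbonyl oxygen in place of the sulfur, or a longer chain on the nitrogen of the entering group, would read closer to compound 1. They also leave open whether this change at the double-bonded ring carbon would give a similar step with trifluoromethyl in place of nitro.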